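Removing the Chloro from Compound 3: What to Expect

A few compounds are considered here, and "the series" means these few. Any claim that something is new, unique, unknown or untested is made for them only; others in the source may bear on it.

Compound 1, `O=C(COc1ccc(C(=O)/C=C/c2ccccc2Cl)cc1)N[C@H]1CCOC1=O`, gives 3240 nM.
Compound 2, `O=C(COc1ccc(C(=O)/C=C/c2cccc(Br)c2)cc1)N[C@H]1CCOC1=O`, gives 9800 nM.
Compound 3, `O=C(COc1ccc(C(=O)/C=C/c2cccc(Cl)c2)cc1)N[C@H]1CCOC1=O`, gives 3700 nM.

All three share one core and differ only in the substituted phenyl on the ethenyl chain. In a functional assay on DU-145 cells (Homo sapiens) for antiproliferative activity, read by MTT assay, with a stated time of 72 h (a lower number here means a stronger inhibitor, a higher number a weaker inhibitor), compound 3 holds the second highest of the three numbers. Its nearest neighbour lies within the scatter: a 1.1-fold higher number from compound 1 to compound 3 (0.06 log units; within the scatter). Its furthest lies beyond it: a 2.6-fold lower number from compound 2 to compound 3 (0.42 log units; beyond the scatter).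

Compound 4, `O=C(COc1ccc(C(=O)/C=C/c2ccccc2)cc1)N[C@H]1CCOC1=O`, has not been measured. The change from compound 3 is hydrogen in place of chloro on an aromatic carbon.

Within the data shown here, no measured step removes a halogen outright. The steps that come closest are a 2.6-fold lower number from compound 2 to compound 3 (0.42 log units; beyond the scatter), a modest shift between two halogens, and a 3.0-fold higher number from compound 1 to compound 2 (0.48 log units; beyond the scatter); the step of a 1.1-fold higher number from compound 1 to compound 3 (0.06 log units; within the scatter) shows that moving the chloro alone changes little. Taking the halogen away is therefore expected to cost at most a modest amount, with a step that may not clear the scatter. Compound 4 is estimated at 5500 nM, with a range from 2600 nM to 12000 nM, meaning an expected step of a 1.5-fold higher number from compound 3 to compound 4 (0.17 log units; within the scatter).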

Compound 4, half-maximal inhibitory concentration: 48300 nM
Compound 4: the middle estimate sits 8.8-fold (0.94 log units) below what was measured; the measured number lies above the stated range.
By their numbers in this assay, from the lowest: compounds 1 and 3 (each within the scatter of the next); then compound 2; then compound 4.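

In this assay, the phenyl without a halogen stands apart from all three halogenated compounds, so having a halogen on this ring counts for more here than the earlier swaps of halogen or chloro position suggested: taking away the chloro gives a 13-fold higher number from compound 3 to compound 4 (1.12 log units; beyond the scatter), and the same loss from the other chloro compound gives a 15-fold higher number from compound 1 to compound 4 (1.17 log units; beyond the scatter). Even the bromo compound, the highest number among the halogenated three, keeps a clear margin, since replacing its bromo with hydrogen gives a 4.9-fold higher number from compound 2 to compound 4 (0.69 log units; beyond the scatter). Nothing available explains why this single atom change carries so much weight.

The compounds shown leave open whether a halogen is specifically required or whether another group on this ring, such as fluoro, methoxy or an amine, would also keep the number low. They also leave open how a second chloro on the same ring would compare.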